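Trading a ring for an open chain

This account rests on a few compounds, and the source may have more. Where it says the series, first, only, none or still open, it means among the compounds named here.

Compound 1 `CC(C)=CC[C@@H](OC(=O)c1ccco1)C1=CC(=O)c2c(O)ccc(O)c2C1=O`: > 100000 nM (a limit)
Compound 2 `CC(C)=CC[C@@H](OC(=O)C1CCCO1)C1=CC(=O)c2c(O)ccc(O)c2C1=O`: 10500 nM

These values come from a functional assay on DU-145 cells (Homo sapiens) for cytotoxicity, read by MTT assay; a higher number here means a weaker inhibitor, a lower number a stronger inhibitor. Going by the values given here, compound 2 holds the only exact number, 10500 nM. Compound 1 reaches only a limit of this assay, > 100000 nM.

Compound 3 `CCCC(C)(O)CC(=O)O[C@H](CC=C(C)C)C1=CC(=O)c2c(O)ccc(O)c2C1=O` has 2-hydroxy-2-methylpentyl in place of oxolan-2-yl on a carbonyl carbon. Among the compounds with values here, the only measured step, an at least 9.5-fold lower number from compound 1 to compound 2 (0.97 log units; beyond the scatter), changes a group at this same place, so the group can matter, but it involves no open chain. No clear direction is therefore expected, and the expected change is small: a 1.3-fold lower number from compound 2 to compound 3 (0.12 log units; within the scatter). The estimated value for compound 3 is 8000 nM, with an expected range of 2500 nM to 30000 nM.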

Compound 3, half-maximal inhibitory concentration: 75000 nM
Beside the measured number, compound 3's estimate is 9.4-fold (0.97 log units) below it; the measured number lies above the stated range.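

Replacing oxolan-2-yl with the open 2-hydroxy-2-methylpentyl gives a 7.1-fold higher number from compound 2 to compound 3 (0.85 log units; beyond the scatter), so on this carbonyl carbon an open chain can cost activity, and the group's shape here is not a matter of the ring type alone. Of the three compounds, the one with oxolan-2-yl, compound 2, has the lowest number. The remaining step, an at least 1.3-fold lower number from compound 1 to compound 3 (0.12 log units; that floor lies within the scatter), cannot be read as a real difference, because one end of it is a limit of the assay: the limit of > 100000 nM in this assay, at which 1 of the 3 values shown sits.

Still open, on these data alone, is whether the higher number follows from losing the ring or from gaining the hydroxy group. A plain hexyl chain on the same carbonyl carbon would help separate the two.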